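A Chloro for a Cyano in a Weak Quinolone Series

A few compounds are considered here, and "the series" means these few. Any claim that something is new, unique, unknown or untested is made for them only; others in the source may bear on it.

compound 1 `COc1ccc(-c2cc(=O)c3c(OC)cc(OC)cc3n2C)cc1`: 30000 nM
compound 2 `COc1ccc(-c2cc(=O)c3c(OC)cc(OC)cc3n2S(=O)(=O)c2ccc([N+](=O)[O-])cc2)cc1`: 17300 nM
compound 3 `COc1ccc(-c2cc(=O)c3c(OC)cc(OC)cc3n2S(=O)(=O)c2ccc(C#N)cc2)cc1`: > 17200 nM

In a functional assay on KOPN-8 cells (Homo sapiens) for antiproliferative activity, with a stated time of 72 h (on this read-out higher numbers stand for an effect only at larger amounts of compound and lower numbers for an effect already at smaller amounts), compound 1 gives 30000 nM and compound 2 gives 17300 nM. For compound 3 only the limit > 17200 nM is reported, not a number, so compound 3 stands at the edge of this assay without a value of its own. Compound 4 `COc1ccc(-c2cc(=O)c3c(OC)cc(OC)cc3n2S(=O)(=O)c2ccc(Cl)cc2)cc1` differs from compound 3 by chloro in place of cyano on an aromatic carbon. Among the compounds with values here, the steps that bear on this change are a step that the limit leaves unreadable from compound 1 to compound 3 and a step that the limit leaves unreadable from compound 2 to compound 3; both end at the limit of > 17200 nM in this assay, at which 1 of the 3 values shown sits, so their sizes cannot be read. No readable step is available for exchanging the group on the sulfonyl ring, and for compound 4 no step beyond the scatter is expected, a number no higher from compound 3 to compound 4 (the limit leaves the size open). Compound 4 is estimated at 17200 nM, within 8000 nM to 40000 nM, quite possibly again only a limit.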

Compound 4, half-maximal effective concentration: > 34400 nM
Compound 4: a limit, no number; the forecaster's own chance of this, stated with the estimate: 70%; middle value at least 2.0-fold (0.30 log units) away from the limit.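

In this assay compound 4 is reported only as a limit, > 34400 nM. Chloro in place of nitro gives an at least 1.9-fold higher number from compound 2 to compound 4 (0.29 log units; that floor lies within the scatter), and the (4-chlorophenyl)sulfonyl group in place of methyl gives an at least 1.1-fold higher number from compound 1 to compound 4 (0.05 log units; that floor lies within the scatter), so neither exchange shows a change beyond the scatter. The step for chloro in place of cyano cannot be read, with limits at both ends. As far as these compounds go, whether an amine or a carboxylic acid in this place on the sulfonyl ring would give a measurable number remains open. So does the true position of compound 3 and compound 4.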